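The compounds below may be only part of what the source reports. "The series", "measured", "known", "first", "only" and "open" are said of these compounds alone.

Working notes on the series in a functional assay on KOPN-8 cells (Homo sapiens) for antiproliferative activity, with a stated time of 72 h; a lower number here means that less compound is needed, a higher number that more compound is needed for the effect. Compound 1, `COc1ccc(-c2cc(=O)c3c(OC)cc(OC)cc3n2Cc2ccccc2)cc1`, gives only a limit of the assay here, > 17300 nM, and no number. Compound 2, `COc1ccc(-c2cc(=O)c3c(OC)cc(OC)cc3n2S(=O)(=O)c2ccc(C=O)cc2)cc1`, likewise gives only a limit, > 34400 nM, and no number. For the measured compounds named here, the step that the two limits leave unreadable from compound 1 to compound 2 therefore cannot be read; the two records the limit of > 17300 nM in this assay, at which 1 of the 2 values shown sits, and the limit of > 34400 nM in this assay, at which 1 of the 2 values shown sits, show only that neither compound reaches a measurable half-maximal effective concentration within the tested range.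

Compound 3, `COc1ccc(-c2cc(=O)c3c(OC)cc(OC)cc3n2S(=O)(=O)c2ccc([N+](=O)[O-])cc2)cc1`, carries the change (nitro in place of formyl on an aromatic carbon), nitro in place of formyl on an aromatic carbon, para to a large group. Going by the values given here, no measured step bears on this change, and the one step available is itself unreadable. Compound 2 stands at a limit, so the expectation for compound 3 is that it also falls at or near a limit, with the step that the limit leaves unreadable from compound 2 to compound 3 estimated as no change beyond the scatter. Compound 3 is thus estimated at 40000 nM, within 8000 nM to 200000 nM.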

Compound 3, half-maximal effective concentration: 17300 nM
Beside the measured number, compound 3's estimate is 2.3-fold (0.36 log units) above it, within the range that was stated.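

Among the compounds shown, compound 3 is the only one with a number rather than a limit in this assay, so this position, para to a large group, can carry a group that leaves a readable value. Nitro in place of formyl on this aromatic carbon gives an at least 1.9-fold lower number from compound 2 to compound 3 (0.29 log units; that floor lies within the scatter), which fixes only a floor for the step and does not separate it from the scatter. Compound 2 remains a limit, so the true size of the step stays unknown: the limit of > 34400 nM in this assay, at which 1 of the 3 values shown sits.

With a single number in the series, no trend can be drawn across the position, and the other steps cannot be read. From the compounds shown here alone, how an amine or a carboxylic acid in this same place would compare with nitro remains open, as does whether nitro would give a number with benzyl on the aromatic nitrogen.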